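This account rests on a few compounds, and the source may have more. Where it says the series, first, only, none or still open, it means among the compounds named here.

Among the compounds with values here, in an ADME assay on LLC-MK2 cells (Macaca mulatta) for cytotoxicity, read by spectrophotometry and crystal violet staining, with a stated time of 4 days (a lower number here means that less compound is tolerated, a higher number that more compound is tolerated), the three measured members spread over a modest range. Compound 1 `CC(C)n1ncc2c(C(=O)Nc3cccc(F)c3F)cc(-c3cccs3)nc21` gives 75000 nM. Compound 2 `CC(C)n1ncc2c(C(=O)Nc3ccc(F)c(F)c3)cc(-c3cccs3)nc21` returns only a limit, > 200000 nM. Compound 3 `CC(C)n1ncc2c(C(=O)Nc3ccccc3S(N)(=O)=O)cc(-c3cccs3)nc21` gives 25000 nM, the lowest of the two actual numbers in this assay; the nearest number is that of compound 1, separated by a 3.0-fold lower number from compound 1 to compound 3 (0.48 log units; beyond the scatter). Against compound 2 the step is an at least 8.0-fold lower number from compound 2 to compound 3 (0.90 log units; beyond the scatter), bounded on one side by the limit of > 200000 nM in this assay, at which 1 of the 3 values shown sits.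

Compound 4 `CC(C)n1ncc2c(C(=O)Nc3ccc(F)cn3)cc(-c3cccs3)nc21` is the next member, not yet measured in this assay. It differs from compound 3 in one place: 5-fluoropyridin-2-yl in place of 2-sulfamoylphenyl on an amide-type nitrogen. Within the data shown here, the steps that bear on this change are the two that introduced the 2-sulfamoylphenyl group, a 3.0-fold lower number from compound 1 to compound 3 (0.48 log units; beyond the scatter) and an at least 8.0-fold lower number from compound 2 to compound 3 (0.90 log units; beyond the scatter); in both cases a difluorophenyl amide sat at a higher number than the 2-sulfamoylphenyl amide. Taking the 2-sulfamoylphenyl away again and placing a 5-fluoropyridin-2-yl on the amide-type nitrogen is therefore expected to move the number upward, by roughly a 3.0-fold higher number from compound 3 to compound 4 (0.48 log units; beyond the scatter). Compound 4 is estimated at 75000 nM, within a range from 25000 nM to 200000 nM, and a reading that is only a limit is possible.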

Compound 4, half-maximal cytotoxic concentration: > 200000 nM
Compound 4 gave a limit, no number; the forecaster's own chance of this, stated with the estimate: 25%; at least 2.6-fold (0.42 log units) between middle value and limit.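

The 2-sulfamoylphenyl group has now been replaced by a ring with a hetero atom, not only by a difluorophenyl, and in this assay the number still rises, with an at least 8.0-fold higher number from compound 3 to compound 4 (0.90 log units; beyond the scatter) as the step at this amide-type nitrogen. The change from 2,3-difluorophenyl to 5-fluoropyridin-2-yl also shows that compound 1 does not mark the upper end of tolerated groups at this position, with an at least 2.6-fold higher number from compound 1 to compound 4 (0.42 log units; beyond the scatter) standing beyond the scatter. Compound 2 and compound 4 both stand at the limit, so the step between them cannot be read and no order between these two groups can be given: the limit of > 200000 nM in this assay, at which 2 of the 4 values shown sit.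

Going by these compounds, how far compound 2 and compound 4 would lie beyond that limit remains open, and so does whether the 5-fluoropyridin-2-yl group differs from the 3,4-difluorophenyl group at all in this assay. Also open, on these data alone, is whether the lower number of compound 3 belongs to the sulfamoyl group itself, as a carboxylic acid or an amine in its place on the phenyl ring would help to show.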